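Replacing 2-methyl-1,3-thiazol-4-yl with 1H-pyrazol-3-yl

The source may report more compounds than this note shows. Statements on the series, on what has been measured and on what is new or still open speak of the compounds shown alone.

Of the compounds shown here, three built on one shared core have been measured in an assay on microsomes from intestine for inhibition of acyl-CoA:cholesterol acyltransferase (Oryctolagus cuniculus); on this read-out lower numbers stand for stronger inhibition and higher numbers for weaker inhibition. Compound 1 `Cc1cc(C)c(NC(=O)N(Cc2cccc(-c3csc(C)n3)c2)C2CCCCCC2)c(C)c1` gives 180 nM, the highest number of the three. Compound 2 `Cc1cc(C)c(NC(=O)N(Cc2ccc(N3CCN(C)CC3)cc2)C2CCCCCC2)c(C)c1` gives 57 nM, and compound 3 `Cc1cc(C)c(NC(=O)N(Cc2ccc(-n3cccn3)cc2)C2CCCCCC2)c(C)c1` gives 70 nM; the step of a 1.2-fold higher number from compound 2 to compound 3 (0.09 log units; within the scatter) stays within the scatter. Compound 4 `Cc1cc(C)c(NC(=O)N(Cc2cccc(-c3cc[nH]n3)c2)C2CCCCCC2)c(C)c1` differs from compound 1 in one place: 1H-pyrazol-3-yl in place of 2-methyl-1,3-thiazol-4-yl on an aromatic carbon. Going by the values given here, no measured step exchanges groups at that position, so the only guide is indirect: compound 3, which also carries a pyrazolyl group on the six-membered ring, gives 70 nM, whereas compound 1 gives 180 nM. The expected step is a 1.5-fold lower number from compound 1 to compound 4 (0.18 log units; within the scatter), a modest lowering at most. Compound 4 is therefore estimated at 120 nM, within a range from 50 nM to 300 nM.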

Compound 4, half-maximal inhibitory concentration: 65 nM
Beside the measured number, compound 4's estimate is 1.8-fold (0.27 log units) above it; the measured number falls inside the stated range.
By their numbers in this assay, from the lowest: compounds 2, 4 and 3 (each within the scatter of the next); then compound 1.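

Among the compounds shown, this is the only exchange at this position, and in this assay it gives a 2.8-fold lower number from compound 1 to compound 4 (0.44 log units; beyond the scatter). Two five-membered aromatic rings with 2 hetero atoms are therefore not interchangeable here, although the entering ring differs only modestly, with one heavy atom fewer and a hydrogen-bond donor that the leaving ring lacks. No evidence is available to explain the step. Still open, as far as these compounds go, is whether that donor matters, which a methyl group on the pyrazole's ring nitrogen would test. From the compounds shown here alone, how an amine or a carboxylic acid would fare at this position also remains open.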